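Trimming One Methyl from a Urea Nitrogen

The source may report more compounds than this note shows. Statements on the series, on what has been measured and on what is new or still open speak of the compounds shown alone.

Compound 1 `COc1ncc(-c2ccc3nc(NC(=O)N(C)C)nn3c2)cc1NS(=O)(=O)c1ccc(F)cc1` carries a dimethylamino group on the carbonyl carbon of its urea. For the measured compounds named here, in a functional assay on A549 cells (Homo sapiens) for cytotoxicity, read by MTT assay, with a stated time of 72 h (on this read-out lower numbers stand for stronger inhibition and higher numbers for weaker inhibition), compound 1 gives 1190 nM, the second highest of the three numbers so far. Compound 2 `CCCNC(=O)Nc1nc2ccc(-c3cnc(OC)c(NS(=O)(=O)c4ccc(F)cc4)c3)cn2n1` gives 220 nM, and compound 3 `COc1ncc(-c2ccc3nc(NC(=O)NCC(=O)N4CCOCC4)nn3c2)cc1NS(=O)(=O)c1ccc(F)cc1` gives 2570 nM. Compound 4 `CNC(=O)Nc1nc2ccc(-c3cnc(OC)c(NS(=O)(=O)c4ccc(F)cc4)c3)cn2n1` differs from compound 1 in one place: hydrogen in place of methyl on an amide-type nitrogen.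

The step that bears most on this change is a 5.4-fold lower number from compound 1 to compound 2 (0.73 log units; beyond the scatter), which also replaces one methyl on that nitrogen with hydrogen while lengthening the other to propyl. The steps of a 2.2-fold higher number from compound 1 to compound 3 (0.33 log units; beyond the scatter) and a 12-fold higher number from compound 2 to compound 3 (1.07 log units; beyond the scatter) show that the group on the remaining chain carbon can move the number in either direction, so only part of the gain seen in compound 2 can be credited to the hydrogen on the nitrogen. A modest move toward a lower number is therefore expected, a 2.2-fold lower number from compound 1 to compound 4 (0.34 log units; beyond the scatter). Compound 4 is estimated to give 550 nM in this assay, within a range of 220 nM to 1400 nM.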

Compound 4, half-maximal inhibitory concentration: 230 nM
Estimate against measurement, compound 4: 2.4-fold (0.38 log units) above; the measured number falls inside the stated range.
By their numbers in this assay, from the lowest: compounds 2 and 4 (each within the scatter of the next); then compound 1; then compound 3.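

With a single methyl swapped for hydrogen and nothing else altered, the number falls by a 5.2-fold lower number from compound 1 to compound 4 (0.71 log units; beyond the scatter) in this assay, so losing that methyl is enough on its own to produce a shift beyond the scatter. The longer chain of compound 2 adds nothing visible, as the step is a 1.0-fold higher number from compound 2 to compound 4 (0.02 log units; within the scatter) and leaves those two compounds indistinguishable, so the gain in compound 2 need not be credited to its propyl group. The step of an 11-fold lower number from compound 3 to compound 4 (1.05 log units; beyond the scatter) then shows that the (morpholin-4-yl)carbonyl group on the chain of compound 3 is tied to a large rise in the number.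

No available measurement gives a reason for any of these steps. As far as these compounds go, it remains open how a plain amino group on the carbonyl carbon, or a chain ending in a carboxylic acid, would compare.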